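Swapping the isopropyl branch for a dimethylaminoethyl arm

A few compounds are considered here, and "the series" means these few. Any claim that something is new, unique, unknown or untested is made for them only; others in the source may bear on it.

Compound 1: `Cc1ccc(S(=O)(=O)N(C)CC(C)C)cc1C#Cc1cc(Cl)ccc1OCC(=O)O`, 4.2 nM
Compound 2: `CCCS(=O)(=O)c1cccc(C#Cc2cc(F)ccc2OCC(=O)O)c1`, 65 nM
Compound 3: `CCCS(=O)(=O)c1cc(C#Cc2cc(Cl)ccc2OCC(=O)O)c(C)cc1NC(C)=O`, 1.3 nM

Of the compounds shown here, three sharing one core have been tested in an assay on CHO cells for displacement of a labelled ligand from prostaglandin D2 receptor 2 (Homo sapiens), read by scintillation counting; a lower number here means a stronger inhibitor, a higher number a weaker inhibitor. Compound 3 gives 1.3 nM, compound 1 gives 4.2 nM, and compound 2 gives 65 nM. Compound 1 thus stands second highest among the three numbers: its nearest neighbour is compound 3, whose number is lower by an amount beyond the usual scatter, while compound 2 lies furthest away, with a higher number, again beyond the scatter.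

Compound 4, `Cc1ccc(S(=O)(=O)N(C)CCCN(C)C)cc1C#Cc1cc(Cl)ccc1OCC(=O)O`, has not yet been measured in this assay. Within the data shown here, its only change from compound 1 is 2-(dimethylamino)ethyl in place of isopropyl on a saturated chain carbon bound to a sulfonamide nitrogen. Put another way, the isobutyl group on the sulfonamide nitrogen becomes a 3-(dimethylamino)propyl group, so the chain grows by the counted two heavy atoms and gains one hydrogen-bond acceptor.

Among the measured compounds shown here, no pair among the measured compounds shows what this kind of change does, so there is no measured step to lean on. The expectation is a modest step toward a higher number, of a size that may not clear the scatter, with the estimated step of a 2.4-fold higher number from compound 1 to compound 4 (0.38 log units; beyond the scatter). Compound 4 is therefore estimated at 10 nM, within a range from 3 nM to 40 nM.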

Compound 4, inhibition constant: 287 nM
For compound 4 the middle estimate is 29-fold (1.46 log units) below the measured one, and the stated range ends below it.
By their numbers in this assay, from the lowest: compound 3; then compound 1; then compound 2; then compound 4.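

In this assay, the group on the sulfonamide nitrogen proves to matter a great deal: replacing isobutyl with 3-(dimethylamino)propyl, with nothing else changed, gives a 68-fold higher number from compound 1 to compound 4 (1.83 log units; beyond the scatter) and counts as a large step. The earlier compounds shown here differ from one another in more than one place, so none of them could show how much this single group counts on its own. The data at hand offer no explanation for the size of this step.

The change adds chain length and a nitrogen together, so the compounds shown leave open which of the two goes with the higher number; a pentyl group on the same sulfonamide nitrogen, built from carbon alone, would help pull these two apart. They also leave open whether the nitrogen's form matters, which a 3-methoxypropyl group, with an oxygen in that role, or a 3-aminopropyl group, with a primary amine, could test, and whether the same step would appear on a core carrying the other substituents seen in compound 3.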